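Swapping a pyridine for a cyclopropane on the azetidine

A few compounds are considered here, and "the series" means these few. Any claim that something is new, unique, unknown or untested is made for them only; others in the source may bear on it.

Measured so far:
compound 1, `COc1ccncc1-c1ccc(COC2CN(C#N)C2)cc1` — 40 nM
compound 2, `COc1ccc(-c2ccc(COC3(c4cccnc4)CN(C#N)C3)c(F)c2)cc1F` — 4.6 nM

Compound 1 `COc1ccncc1-c1ccc(COC2CN(C#N)C2)cc1` was tested in an assay on isolated protein for inhibition of N-acylethanolamine-hydrolyzing acid amidase (Homo sapiens), read by fluorescence, with a stated time of 90 min (a higher number here means a weaker inhibitor, a lower number a stronger inhibitor), and gives 40 nM. Compound 2 `COc1ccc(-c2ccc(COC3(c4cccnc4)CN(C#N)C3)c(F)c2)cc1F` in this assay gives 4.6 nM, the lower of the two numbers and so the stronger inhibitor of the pair, with compound 1 standing well beyond the usual scatter above it.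

Compound 3 `COc1ccc(-c2ccc(COC3(C4CC4)CN(C#N)C3)c(F)c2)cc1F` differs from compound 2 in one place: cyclopropyl in place of pyridin-3-yl on a saturated ring carbon. Among the measured compounds shown here, nothing measured yet shows what this swap does, since no two measured compounds differ only here. A small loss of inhibition seems the more likely outcome, though a step inside the scatter is also possible. Compound 3 is therefore expected to give about 11 nM in this assay, somewhere between 3 nM and 40 nM, a step of a 2.4-fold higher number from compound 2 to compound 3 (0.38 log units; beyond the scatter) that is estimated rather than known.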

Compound 3, half-maximal inhibitory concentration: 0.35 nM
Beside the measured number, compound 3's estimate is 31-fold (1.50 log units) above it, and the stated range ends above it.
By their numbers in this assay, from the lowest: compound 3; then compound 2; then compound 1.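

In this assay the saturated ring carbon of the four-membered ring turns out to be a place where the choice of group matters greatly: the change gives a 13-fold lower number from compound 2 to compound 3 (1.12 log units; beyond the scatter) and lies well beyond the scatter. Pyridin-3-yl, with its six heavy atoms and one hydrogen-bond acceptor, is therefore not required here for strong inhibition, since cyclopropyl, with three heavy atoms and no acceptor, does far better on the same core. Nothing at hand explains why this swap helps so much.

On these data alone, it remains open whether the gain is particular to cyclopropyl or would also come with other groups on this carbon, such as methyl, isopropyl or cyclobutyl. As far as these compounds go, it is also open whether cyclopropyl would do the same on the core of compound 1.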